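Swapping the Amine Tail on a Second Core

A few compounds are considered here, and "the series" means these few. Any claim that something is new, unique, unknown or untested is made for them only; others in the source may bear on it.

Three compounds share a quinazoline-based core and were tested in a functional assay on PC-3 cells (Homo sapiens) for antiproliferative activity, read by MTT assay, with a stated time of 72 h; a lower number here means a stronger inhibitor, a higher number a weaker inhibitor. Compound 1 `COc1cc2ncnc(N3CCc4ccccc43)c2cc1NC(=O)/C=C/CN1CCN(C)CC1` gives 9180 nM in this assay. Compound 2 `COc1cc2ncnc(N3CCc4ccccc43)c2cc1NC(=O)/C=C/CN1CCC(CO)CC1` gives 2650 nM, and compound 3 `COc1cc2ncnc(N3CCCc4ccccc43)c2cc1NC(=O)/C=C/CN1CCN(C)CC1` gives 6260 nM.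

Compound 1 and compound 2 differ in one place, (4-(hydroxymethyl)piperidin-1-yl in place of 4-methylpiperazin-1-yl on a saturated chain carbon bound to a double-bonded chain carbon). This change gave a 3.5-fold lower number from compound 1 to compound 2 (0.54 log units; beyond the scatter). Compound 1 and compound 3 differ instead in their cores, (1,2,3,4-tetrahydroquinolin-1-yl in place of 2,3-dihydro-1H-indol-1-yl on an aromatic carbon), and that change gave a 1.5-fold lower number from compound 1 to compound 3 (0.17 log units; within the scatter), so the two cores cannot be told apart on these numbers alone.

Compound 4 `COc1cc2ncnc(N3CCCc4ccccc43)c2cc1NC(=O)/C=C/CN1CCC(CO)CC1` has not yet been measured in this assay. It carries the core of compound 3 together with the tail of compound 2, so that compound 3 and compound 4 differ by 4-(hydroxymethyl)piperidin-1-yl in place of 4-methylpiperazin-1-yl on a saturated chain carbon bound to a double-bonded chain carbon. The place of this change reads the same, word for word, as for compound 1 and compound 2, so it is the same change made on the other core.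

He therefore expects the step from compound 3 to compound 4 to come out as a 3.5-fold lower number from compound 3 to compound 4 (0.54 log units; beyond the scatter), beside the earlier one, because of a 3.5-fold lower number from compound 1 to compound 2 (0.54 log units; beyond the scatter). On that basis compound 4 is estimated to give 1800 nM in this assay, with a range from 800 nM to 4000 nM; the estimate rests on a single precedent and on the core step being within the scatter.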

Compound 4, half-maximal inhibitory concentration: 7150 nM
For compound 4 the middle estimate is 4.0-fold (0.60 log units) below the measured one, outside the stated range (above it).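

In this assay the exchange of 4-methylpiperazin-1-yl for 4-(hydroxymethyl)piperidin-1-yl gave a 1.1-fold higher number from compound 3 to compound 4 (0.06 log units; within the scatter), so the step seen on the core of compound 1 did not carry over to the core of compound 3: the same change on two cores in this assay, a 3.5-fold lower number (0.54 log units; beyond the scatter) from compound 1 to compound 2 and a 1.1-fold higher number (0.06 log units; within the scatter) from compound 3 to compound 4, 4.0-fold (0.60 log units) apart, beyond the scatter of two such steps

Read the other way, the core change that made no clear difference with the 4-methylpiperazin-1-yl tail gave a 2.7-fold higher number from compound 2 to compound 4 (0.43 log units; beyond the scatter) with the 4-(hydroxymethyl)piperidin-1-yl tail, so in these compounds the effects of tail and core do not simply add: the same change on two cores in this assay, a 1.5-fold lower number (0.17 log units; within the scatter) from compound 1 to compound 3 and a 2.7-fold higher number (0.43 log units; beyond the scatter) from compound 2 to compound 4, 4.0-fold (0.60 log units) apart, beyond the scatter of two such steps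

This shows that a tail step in this series cannot be assumed to transfer from one core to the other, but it rests on a single set of four compounds in one assay, so it neither explains the difference nor shows how any other tail would behave on these cores.

The compounds shown leave open whether a morpholin-4-yl or a dimethylamino group at the end of the chain would also behave differently on the two cores. They also leave open whether a longer chain would change the picture for either tail.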